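The source may report more compounds than this note shows. Statements on the series, on what has been measured and on what is new or still open speak of the compounds shown alone.

Compound 1 `FC(F)(F)c1cc(NC[C@H]2CCCCN2)c2cn[nH]c2c1` gives 90% in an assay for inhibition of Tryptophan 2,3-dioxygenase (Homo sapiens), with stated times of 10 min and 60 min, tested at 100 uM; a higher number here means a stronger effect of the compound at the concentration tested, a lower number a weaker effect. Compound 2 `Nc1cccc(CNc2cc(C(F)(F)F)cc3[nH]ncc23)c1` gives 89% in this assay, the step being a number 1 percentage points lower from compound 1 to compound 2 (within the scatter). Going by the values given here, on the two numbers at hand compound 2 stands lowest, but its only neighbour, compound 1, lies within the scatter of it, so no order can be read between the two. Compound 3 `FC(F)(F)c1cc(NCc2cccc(Br)c2)c2cn[nH]c2c1` differs from compound 2 by bromo in place of amino on an aromatic carbon. Among the compounds with values here, the single measured step, a number 1 percentage points lower from compound 1 to compound 2 (within the scatter), concerns the group on the saturated chain carbon and not the aromatic carbon changed here, so nothing measured bears directly on the new step. With both measured compounds near the top of the scale, the step expected in this assay for compound 3 is a number 4 percentage points lower from compound 2 to compound 3 (within the scatter), none beyond the scatter. Compound 3 is therefore estimated at 85% in this assay, with a range from 60% to 98%.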

Compound 3, a percentage reported as inhibition, at one concentration (the size of the read-out at that concentration, not a potency): 84%
The estimate for compound 3 lay 1 percentage points above the measured number; the measured number falls inside the stated range.
By their numbers in this assay, from the lowest: compounds 3, 2 and 1 (each within the scatter of the next).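

Bromo in place of amino on an aromatic carbon, meta to a large group, gives a number 5 percentage points lower from compound 2 to compound 3 (within the scatter) in this assay, so the first measured change at this aromatic carbon shows that amino, with its hydrogen-bond donor and acceptor, can give way to bromo, which has neither, without a readable difference at this concentration. The wider comparison on the saturated chain carbon, a number 6 percentage points lower from compound 1 to compound 3 (within the scatter), likewise leaves 3-bromophenyl indistinguishable from piperidin-2-yl, as 3-aminophenyl already was. No measurement at hand speaks to the reason for these results.

As each number comes from a single concentration, the three compounds cannot be separated by potency. From the compounds shown here alone, it remains open whether a carboxylic acid or a nitrile on this aromatic carbon, or a longer chain on the ring nitrogen's substituent, would give a step beyond the scatter.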